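The source may report more compounds than this note shows. Statements on the series, on what has been measured and on what is new or still open speak of the compounds shown alone.

Measured compounds:
compound 1, `Nc1scc(-c2ccccc2)c1C(=O)c1ccc(Cl)cc1`; in a functional assay on CHO cells for agonist activity at adenosine receptor A1 (Homo sapiens), read by fluorescence and ERK phosphorylation, with stated times of 30 min and 1.5 h, tested at 10 uM (on this read-out higher numbers stand for a stronger effect at the one concentration tested and lower numbers for a weaker effect), compound 1 gives 64%
compound 2, `Nc1scc(-c2ccccc2F)c1C(=O)c1ccc(Cl)cc1`; in this assay compound 2 gives 87%

For the measured compounds named here, compound 2 holds the higher of the two numbers in this assay; its only neighbour is compound 1, and the step of a number 23 percentage points higher from compound 1 to compound 2 (beyond the scatter) lies beyond the scatter, so compound 2 is the stronger of the pair on this read-out.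

The next compound, compound 3, `Nc1scc(-c2cccc(F)c2)c1C(=O)c1ccc(Cl)cc1`, has not been measured. Its change from compound 2 is 3-fluorophenyl in place of 2-fluorophenyl on an aromatic carbon.

Going by the values given here, only one measured step exists, fluoro in place of hydrogen on an aromatic carbon, which gave a number 23 percentage points higher from compound 1 to compound 2 (beyond the scatter). Among the compounds with values here, that step concerns the presence of the fluorine on the phenyl, not its position, and no measured pair differs in the position of a fluorine, so the bearing on compound 3 is indirect. The number for compound 3 is therefore expected to sit between those of compound 1 and compound 2, which means an expected step of a number 12 percentage points lower from compound 2 to compound 3 (beyond the scatter), a decrease that may or may not reach beyond the scatter. The estimate for compound 3 in this assay is 75%, expected within 55% to 93%.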

Compound 3, a percentage reported as activity, at one concentration (the size of the read-out at that concentration, not a potency): 90%
The estimate for compound 3 lay 15 percentage points below the measured number; low and high end bracket the measured number.
By their numbers in this assay, from the lowest: compound 1; then compounds 2 and 3 (each within the scatter of the next).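

Shifting the fluorine on the phenyl carried by the aromatic carbon two ring bonds from the ring sulfur, with 3-fluorophenyl in place of 2-fluorophenyl, gives a number 3 percentage points higher from compound 2 to compound 3 (within the scatter) in this assay so on this read-out the two fluorine placements are not told apart, a point the earlier pair could not address. The second fluoro-for-hydrogen step, a number 26 percentage points higher from compound 1 to compound 3 (beyond the scatter) joins a number 23 percentage points higher from compound 1 to compound 2 (beyond the scatter) as a rise beyond the scatter, so the gain over the plain phenyl of compound 1 no longer rests on a single fluorine placement, though it still rests on only these two compounds. Nothing available bears on the reason for any of these steps.

Open is whether the rise belongs to fluorine itself or would also appear with another group on the phenyl, such as chlorine, methoxy, a dimethylamino group or a carboxylic acid, and whether 4-fluorophenyl would fall in line with the two placements shown. Since the read-out reports the size of the effect at one concentration only, the compounds also leave open how compound 2 and compound 3 would compare at any other concentration.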